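A few compounds are considered here, and "the series" means these few. Any claim that something is new, unique, unknown or untested is made for them only; others in the source may bear on it.

Measured compounds in this series:
compound 1 `CCOC(=O)CCCCCOc1cccc(CN(C(=O)c2ccc(-c3cccc(OCC(C)C)c3)cc2)C(C)C)c1` — > 26000 nM
compound 2 `CCOC(=O)CCCCCOc1cccc(CN(C(=O)c2ccc(-c3ccoc3)cc2)C(C)C)c1` — > 26000 nM
compound 3 `CCOC(=O)CCCCCOc1cccc(CN(C(=O)c2ccc(-c3ccco3)cc2)C(C)C)c1` — > 26000 nM

In an ADME assay on HepG2 cells (Homo sapiens) for cytotoxicity, read by CellTiter-Glo and resazurin assay, with a stated time of 72 h (a lower number here means that less compound is needed, a higher number that more compound is needed for the effect), compound 1 gives > 26000 nM, which is a limit of the assay and not a number. Compound 2 likewise gives > 26000 nM, a limit. Compound 3 sits at > 26000 nM, also a limit, and the limit of > 26000 nM in this assay, at which 3 of the 3 values shown sit, describes where all three stand. Compound 3 therefore has no number of its own in this assay, only the limit shared with the other two.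

The measured steps cannot be sized: a step that the two limits leave unreadable from compound 1 to compound 2, a step that the two limits leave unreadable from compound 1 to compound 3 and a step that the two limits leave unreadable from compound 2 to compound 3 all fall between two limits, so none of them shows a direction or a size.

The next compound is compound 4 `CCOC(=O)CCCCCOc1cccc(CN(C(=O)c2ccc(-c3cccc(O)c3)cc2)C(C)C)c1`. It differs from compound 3 as follows: 3-hydroxyphenyl in place of furan-2-yl on an aromatic carbon. Among the measured compounds shown here, no measured step involves the 3-hydroxyphenyl group, so the three unreadable steps offer no guidance on direction, and the only information is that every compound so far reached the limit in this assay.

Compound 4 is therefore expected to stand at 30000 nM, with a range from 15000 nM to 60000 nM, most probably again reported as a limit. The expected step, a step that the limit leaves unreadable from compound 3 to compound 4, is an estimate of no change beyond the scatter.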

Compound 4, half-maximal effective concentration: > 26000 nM
Compound 4: a limit, no number; the forecaster's own chance of this, stated with the estimate: 85%; the middle value does not contradict the limit.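

In this assay, among the compounds shown here, compound 4 gives > 26000 nM, a limit and not a number, so no step from compound 4 to compound 1, compound 2 or compound 3 can be read: the limit of > 26000 nM in this assay, at which 4 of the 4 values shown sit. The compounds shown leave open how far any of the four lies from that limit, and whether exchanging the group on the aromatic carbon changes anything in this assay.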